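From 4-fluorophenyl to 3-fluorophenyl on the shared core

The compounds below may be only part of what the source reports. "The series", "measured", "known", "first", "only" and "open" are said of these compounds alone.

In a functional assay on HepG2 cells (Homo sapiens) for inhibition, read by fluorescence and resazurin assay, with a stated time of 72 h (a higher number here means a weaker inhibitor, a lower number a stronger inhibitor), compound 1 `O=C1NC(Cc2ccc(Nc3nccc(Nc4ccc5cn[nH]c5c4)n3)cc2)CO1` gives 20000 nM and compound 2 `c1cc(Nc2ccc3cn[nH]c3c2)nc(Nc2ccc(Cn3cncn3)cc2)n1` gives 18000 nM. Compound 3 `O=C(Nc1ccc(F)cc1)Nc1ccc(Nc2nccc(Nc3ccc4cn[nH]c4c3)n2)cc1` is the strongest inhibitor of the three, at 3500 nM. Two measured steps lead to it, a 5.7-fold lower number from compound 1 to compound 3 (0.76 log units; beyond the scatter) and a 5.1-fold lower number from compound 2 to compound 3 (0.71 log units; beyond the scatter), and both bring in the ((4-fluorophenyl)carbamoyl)amino group. Compound 4 `O=C(Nc1ccc(Nc2nccc(Nc3ccc4cn[nH]c4c3)n2)cc1)Nc1cccc(F)c1` keeps that group's place but carries 3-fluorophenyl in place of 4-fluorophenyl on an amide-type nitrogen. Going by the values given here, neither step moves the fluorine, so the data offer no direct precedent, and no direction can be favoured with confidence. The expected step, within the scatter, is a 1.2-fold lower number from compound 3 to compound 4 (0.07 log units; within the scatter). Compound 4 is estimated at 3000 nM, with an expected range of 1200 nM to 8000 nM.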

Compound 4, half-maximal inhibitory concentration: 6600 nM
Estimate against measurement, compound 4: 2.2-fold (0.34 log units) below; low and high end bracket the measured number.
By their numbers in this assay, from the lowest: compounds 3 and 4 (each within the scatter of the next); then compounds 2 and 1 (each within the scatter of the next).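

Exchanging 4-fluorophenyl for 3-fluorophenyl on the amide-type nitrogen (a 1.9-fold higher number from compound 3 to compound 4 (0.28 log units; within the scatter)) shows that moving the fluorine at this place makes no difference that can be told from the scatter. The ((3-fluorophenyl)carbamoyl)amino group also keeps the gain over the other two groups (a 2.7-fold lower number from compound 2 to compound 4 (0.44 log units; beyond the scatter) and a 3.0-fold lower number from compound 1 to compound 4 (0.48 log units; beyond the scatter)), so that gain is not tied to 4-fluorophenyl alone. No measurement at hand accounts for these differences. Still open, on these data alone, is how an unsubstituted phenyl, a 4-chlorophenyl or a cyclohexyl on the same nitrogen would compare with compound 3 and compound 4.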